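Sulfonate series: amide to urea at the anilide nitrogen

The compounds below may be only part of what the source reports. "The series", "measured", "known", "first", "only" and "open" are said of these compounds alone.

Of the compounds shown here, two carry numbers so far. Compound 1 `CC(=O)Nc1ccc(S(=O)(=O)Oc2ccccc2I)cc1` in a functional assay on MCF7 cells (Homo sapiens) for antiproliferative activity, read by sulforhodamine B assay, with a stated time of 48 h (on this read-out higher numbers stand for weaker inhibition and lower numbers for stronger inhibition), gives 27000 nM. Compound 2 `CCC(=O)Nc1ccc(S(=O)(=O)Oc2ccccc2C(C)C)cc1` in this assay gives 11000 nM, the lower of the two numbers, and its gap to compound 1 lies beyond the scatter. The two compounds differ in more than one place, so no single step can be read from that pair.

Compound 3 `CCNC(=O)Nc1ccc(S(=O)(=O)Oc2ccccc2C(C)C)cc1` is the next to be measured in this assay. It differs from compound 2 in one place: ethylamino in place of ethyl on a carbonyl carbon. Among the measured compounds shown here, nothing among the measured compounds speaks to a change of this kind; no step of the sort has been run. The working expectation is therefore a step within the scatter, or at most a small move toward a higher number. Compound 3 is expected to give an estimated 15000 nM in this assay, within a range from 5000 nM to 45000 nM. The expected step is a 1.4-fold higher number from compound 2 to compound 3 (0.13 log units; within the scatter).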

Compound 3, half-maximal inhibitory concentration: 10000 nM
For compound 3 the middle estimate is 1.5-fold (0.18 log units) above the measured one; the range from low to high includes it.
By their numbers in this assay, from the lowest: compounds 3 and 2 (each within the scatter of the next); then compound 1.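

In this assay, replacing ethyl with ethylamino on a carbonyl carbon, which turns propanoylamino into (ethylcarbamoyl)amino, gives a 1.1-fold lower number from compound 2 to compound 3 (0.04 log units; within the scatter). Among the compounds shown here, this is the first step that can be read at a single place, and it shows that at this position, in this one pair, the added nitrogen and the hydrogen-bond donor counted for ethylamino come with no change in the number beyond the scatter, so the amide and urea forms cannot be told apart in this assay. No supporting measurement bears on this result, so nothing can be said about why the two compounds read alike.

For the compounds shown here, compound 1 differs from compound 2 and compound 3 in more than one place, so no step to it can be read, and the separate contributions of its acetyl group and iodo substituent stay unresolved. Also open, from the compounds shown here alone, is whether this flat reading holds for other groups on the same carbonyl carbon, such as dimethylamino, a longer chain such as hexylamino, or a phenylamino group, since a single pair cannot establish a trend at this position.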